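The source may hold more compounds than are shown below. What is called first, only, known or untested is meant among the compounds shown, and "the series" means these compounds.

The study concerns two measured compounds and one that has not yet been measured, compared in an ADME assay on MDCK cells (Canis lupus familiaris) for cytotoxicity, read by microscopy, with a stated time of 6 days; a lower number here means that less compound is tolerated, a higher number that more compound is tolerated. Compound 1 `CCCCCNc1nccnc1C(=O)NCc1ccccc1` returns only a limit of the assay, namely >= 20000 nM, so its true value is not pinned down; this is one of the values that sit at the limit of >= 20000 nM in this assay, at which 1 of the 2 values shown sits. Compound 2 `CCCCCCCCNc1cncc(C(=O)NCc2ccccc2)n1` gives 4000 nM in this assay.

Compound 3 `CCCCCCCCNc1nccnc1C(=O)NCc1ccccc1` shares the core of compound 1 and differs from it by propyl in place of hydrogen on a saturated chain carbon, five bonds along the chain from a nitrogen on an aromatic ring. Going by the values given here, no measured step between two compounds of the set isolates this change, so the direction can only be expected. The step from compound 1 to compound 3 is expected to run toward a lower number, that is toward less compound being tolerated, and the estimated step of an at least 3.3-fold lower number from compound 1 to compound 3 (0.52 log units; beyond the scatter) is expected to lie beyond the usual scatter. Compound 3 is estimated to give 6000 nM in this assay, with a range from 2000 nM to 20000 nM.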

Compound 3, minimum cytotoxic concentration: 100000 nM
Estimate against measurement, compound 3: 17-fold (1.22 log units) below; the measured number lies above the stated range.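

In this assay no step can be read from compound 1 to compound 3, because compound 1 returns only a limit: the limit of >= 20000 nM in this assay, at which 1 of the 3 values shown sits. The compounds shown leave open how large the change from hydrogen to propyl is, and in which direction it runs.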